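An Ethyl Group Replaces Hydrogen on Compound 2

The source may report more compounds than this note shows. Statements on the series, on what has been measured and on what is new or still open speak of the compounds shown alone.

The measured compounds:
compound 1, `COc1ccc2c(=O)c(-c3nn[nH]n3)c[nH]c2c1`: 10 mg/kg
compound 2, `O=c1c(-c2nn[nH]n2)c[nH]c2ccccc12`: 1.25 mg/kg
compound 3, `CC(C)c1cccc2c(=O)c(-c3nn[nH]n3)c[nH]c12`: 1.25 mg/kg

All three were tested in a functional assay on the whole organism (strain Sprague-Dawley) for inhibition, with Rattus norvegicus as the target; on this read-out lower numbers stand for an effect already at smaller amounts and higher numbers for an effect only at larger amounts of compound. Compound 2 and compound 3 stand level at the digits shown and together give the lowest numbers of the three; compound 1 is the furthest away, and the step from compound 1 to compound 2, hydrogen in place of methoxy on an aromatic carbon, was an 8.0-fold lower number from compound 1 to compound 2 (0.90 log units; beyond the scatter). The step from compound 2 to compound 3, isopropyl in place of hydrogen on an aromatic carbon, was no change at the digits printed from compound 2 to compound 3 (within the scatter).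

Compound 4, `CCc1ccc2[nH]cc(-c3nn[nH]n3)c(=O)c2c1`, differs from compound 2 as follows: ethyl in place of hydrogen on an aromatic carbon. Among the compounds with values here, the step that bears most directly on this change is the one from compound 2 to compound 3, where an alkyl group entered on an aromatic carbon and the number stayed where it was. The step from compound 1 to compound 2 concerns a methoxy group and a different position and is less informative. On this basis the account expects a step of about no change at the digits printed from compound 2 to compound 4 (within the scatter) in this assay, that is, no change beyond the scatter, with the ethyl group landing on the six-membered carbon ring meta to one fused ring and para to the other. Compound 4 is therefore estimated at 1.25 mg/kg, with a range from 0.6 mg/kg to 3 mg/kg.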

Compound 4, minimum effective dose: < 5 mg/kg
Compound 4: only a limit was reported; the forecaster's own chance of this, stated with the estimate: 5%; the middle value is on the limit's open side.
By their numbers in this assay, from the lowest: compounds 2 and 3 (each within the scatter of the next); then compound 1.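

In this assay compound 4 is reported only as a limit, < 5 mg/kg. Within the data shown here, no step from compound 2 to compound 4 can be read from this limit. The compounds shown leave open whether ethyl in place of hydrogen on this aromatic carbon changes the number at all, and where compound 4 stands among the others.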